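From Hydroxy to Acetoxy: A Cytotoxicity Step Awaited

This account rests on a few compounds, and the source may have more. Where it says the series, first, only, none or still open, it means among the compounds named here.

In a functional assay on CaEs17 cells (Homo sapiens) for cytotoxicity, read by MTT assay, with a stated time of 72 h (on this read-out lower numbers stand for stronger inhibition and higher numbers for weaker inhibition), compound 1 `C=C1C(=O)[C@@]23C(=O)OC[C@]4(C(=O)CCC(C)(C)[C@H]4C=O)[C@@H]2CC[C@@H]1[C@H]3O` gives 5850 nM, while compound 2 `C=C1C(=O)[C@@]23C(=O)OC[C@]4([C@@H](OC(C)=O)CCC(C)(C)[C@H]4C=O)[C@@H]2CC[C@@H]1[C@H]3O` gives 72600 nM. Compound 1 therefore holds the lower of the two numbers, and the gap between them lies beyond the usual scatter. Compound 3 `C=C1C(=O)[C@@]23C(=O)OC[C@]4(C(=O)CCC(C)(C)[C@H]4C=O)[C@@H]2CC[C@@H]1[C@H]3OC(C)=O` keeps the core of compound 1 and alters it in one place: acetyl in place of hydrogen on an oxygen on a saturated carbon. Here a hydroxy becomes an acetoxy, with acetyl in place of hydrogen on an oxygen on a saturated carbon. Within the data shown here, no measured pair shows this change on its own, so the expectation starts from compound 1 at 5850 nM. In this assay no step beyond the scatter is expected, and no firm direction can be given. The estimated 1.1-fold higher number from compound 1 to compound 3 (0.05 log units; within the scatter) is correspondingly small. Compound 3 is expected to give 6500 nM, within an estimated range of 1800 nM to 23000 nM.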

Compound 3, half-maximal inhibitory concentration: 1350 nM
The estimate for compound 3 lay 4.8-fold (0.68 log units) above the measured number; the whole stated range lies above it.
By their numbers in this assay, from the lowest: compound 3; then compound 1; then compound 2.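

In this assay, among these compounds, the step from hydroxy to acetoxy on this oxygen on a saturated carbon gives a 4.3-fold lower number from compound 1 to compound 3 (0.64 log units; beyond the scatter) and so shows for the first time that this position responds to change. Compounds 1 and 2 both carry the free hydroxy here, so neither could show what acetyl in place of its hydrogen does. The hydroxy hydrogen is thus not needed for the activity seen in this assay, but no measurement at hand bears on why the number falls.

Going by these compounds, whether a longer acyl chain such as butanoyl or a benzoyl group would take the number lower still remains open. So does the effect of an amine or a methyl ether at this position, and whether the step from hydroxy to acetoxy would hold on the core of compound 2.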